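Butyl on the outer ring of compound 2: expected cytotoxicity

This account rests on a few compounds, and the source may have more. Where it says the series, first, only, none or still open, it means among the compounds named here.

Three compounds share a core built on a sugar-like ring carrying a pyrimidinedione, each tested in a functional assay on ACHN cells (Homo sapiens) for cytotoxicity, read by sulforhodamine B assay, tested at 10 uM; a higher number here means more inhibition at the concentration tested (going by the name of the read-out), a lower number less inhibition. Compound 1, `CC(=O)OC[C@H]1O[C@@H](n2cc(-c3cn(Cc4ccc(C(C)C)cc4)nn3)c(=O)[nH]c2=O)C[C@@H]1OC(C)=O`, gives 92.2%. Compound 2, `CC(=O)OC[C@H]1O[C@@H](n2cc(-c3cc(-c4ccccc4)no3)c(=O)[nH]c2=O)C[C@@H]1OC(C)=O`, gives 97.6%. Compound 3, `CC(C)(C)c1ccc(Cn2cc(-c3cn([C@H]4C[C@H](O)[C@@H](CO)O4)c(=O)[nH]c3=O)nn2)cc1`, gives 102%. Compound 2 sits among the three with its number within the usual scatter of both neighbours: compound 3 lies nearest, compound 1 furthest, and neither gap is large enough to count as a real difference. All three numbers, in short, lie level with one another at the tested concentration.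

Compound 4, `CCCCc1ccc(-c2cc(-c3cn([C@H]4C[C@H](OC(C)=O)[C@@H](COC(C)=O)O4)c(=O)[nH]c3=O)on2)cc1`, has not yet been measured. It differs from compound 2 in one place: butyl in place of hydrogen on an aromatic carbon. For the measured compounds named here, no measured pair here shows what such a change does, so the expectation rests on the three numbers themselves. Because compound 2 gives 97.6% and compounds 1 and 3 lie level with it, the step of a number 7.6 percentage points lower from compound 2 to compound 4 (within the scatter) is expected to stay within the scatter, in no clear direction. Compound 4 is therefore estimated at 90%, with a range from 65% to 103%.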

Compound 4, a percentage reported as inhibition, at one concentration (the size of the read-out at that concentration, not a potency): 80.5%
Compound 4: the middle estimate sits 9.5 percentage points above what was measured, and the stated range covers the measured number.
By their numbers in this assay, from the lowest: compound 4; then compounds 1, 2 and 3 (each within the scatter of the next).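

In this assay, for the compounds shown here, the change from phenyl to 4-butylphenyl gives a number 17.1 percentage points lower from compound 2 to compound 4 (beyond the scatter), the first single change in this set to show a difference larger than the usual scatter. This means that the aromatic carbon para to a large group is not a silent position: butyl in place of hydrogen there registers in the read-out, something the three level earlier compounds could not reveal. No measurement shown here accounts for the size or direction of this step.

Going by these compounds, with only butyl tested at this position, it remains open whether a methyl group or a longer chain would give a smaller or larger step. An amine or a carboxylic acid at the same carbon is equally uncharted, so no trend can yet be drawn for this position.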